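The compounds below may be only part of what the source reports. "The series", "measured", "known", "first", "only" and "open" are said of these compounds alone.

Measured compounds:
compound 1 `O=C(Nc1cc(Cl)nc(Cl)c1)Nc1cc2ccc(-c3ccccc3)cn2n1` gives 5130 nM
compound 2 `COc1ccc(-c2ccc3cc(NC(=O)Nc4cc(Cl)nc(Cl)c4)nn3c2)cc1` gives 5350 nM
compound 3 `O=C(Nc1cc(Cl)cc(Cl)c1)Nc1cc(Cl)nc(Cl)c1` gives 11400 nM

The three measured compounds share a dichloropyridyl urea and differ in the aryl partner of the urea. In a functional assay on HCT-116 cells (Homo sapiens) for inhibition, read by MTT assay, with a stated time of 72 h, in the presence of a further agent that is not named here (a higher number here means that more compound is needed for the effect, a lower number that less compound is needed), compound 1 gives 5130 nM and compound 2 gives 5350 nM. The two differ by a single change, (methoxy in place of hydrogen on an aromatic carbon), and the step is a 1.0-fold higher number from compound 1 to compound 2 (0.02 log units; within the scatter). Compound 3 carries a different core; how the core of compound 3 differs from the core of compound 1 is not broken down here. Compound 3 gives 11400 nM, the highest of the three numbers, and its step to either of the other two is beyond the scatter.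

Compound 4 `COc1c(Cl)cc(NC(=O)Nc2cc(Cl)nc(Cl)c2)cc1Cl` is not yet measured. It differs from compound 3 by methoxy in place of hydrogen on an aromatic carbon. Within the data shown here, this is the same kind of change as the one from compound 1 to compound 2, with a difference in surroundings: in compound 4 the methoxy enters ortho to two chloro groups (1 heavy atom each) as well as para to a large group, whereas in compound 2 it enters only para to a large group.

Because the step of a 1.0-fold higher number from compound 1 to compound 2 (0.02 log units; within the scatter) lay within the scatter, the same kind of change on compound 3 is expected to move the number little, and the step from compound 3 to compound 4 is estimated at a 1.0-fold lower number from compound 3 to compound 4 (0.02 log units; within the scatter). Among the measured compounds shown here, only one earlier example of this change exists, so the estimate is held wide. For compound 4 the expected value in this assay is 11000 nM, with a range estimated from 5000 nM to 25000 nM.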

Compound 4, half-maximal effective concentration: 41500 nM
Estimate against measurement, compound 4: 3.8-fold (0.58 log units) below; the whole stated range lies below it.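

In this assay, methoxy in place of hydrogen on an aromatic carbon did not behave on the core of compound 3 as it had on the core of compound 1, for the step is a 3.6-fold higher number from compound 3 to compound 4 (0.56 log units; beyond the scatter), so that more compound is needed for the effect once the methoxy is present. Set beside the earlier example, the change does not carry over as a constant step between these two cores: the same change on two cores in this assay, a 1.0-fold higher number (0.02 log units; within the scatter) from compound 1 to compound 2 and a 3.6-fold higher number (0.56 log units; beyond the scatter) from compound 3 to compound 4, 3.5-fold (0.54 log units) apart, beyond the scatter of two such steps This does not show what sets the two steps apart, since the pairs differ both in the core and in the surroundings of the methoxy, which in compound 4 stands ortho to two chloro groups as well as para to a large group, and in compound 2 only para to a large group; two pairs also give no rule for any other core in the series.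

Open, going by these compounds, is whether the larger step stays when the two chloro groups of compound 4 give way to hydrogen or to fluoro, which would help to separate surroundings from core. Also open, on these data alone, is how a hydroxyl group, an ethoxy group or an amine would read in this assay at the place the methoxy takes in compound 4.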